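Cytotoxicity notes on three measured compounds and compound 4

The compounds below may be only part of what the source reports. "The series", "measured", "known", "first", "only" and "open" are said of these compounds alone.

Measured so far in a toxicity assay on HEK-293T cells (Homo sapiens) for inhibition, read by MTT assay, with a stated time of 24 h; a higher number here means that more compound is tolerated, a lower number that less compound is tolerated:
Compound 1 `O=c1oc2ccccc2c(N2CCN(c3ccccc3)CC2)c1CO` gives > 50000 nM, which is a limit of the assay.
Compound 2 `O=c1oc2ccccc2c(N2CCN(c3ccc(Cl)c(Cl)c3)CC2)c1CO` gives > 50000 nM, which is a limit of the assay.
Compound 3 `COc1ccc(N2CCN(c3c(CO)c(=O)oc4ccccc34)CC2)cc1` gives > 50000 nM, which is a limit of the assay.

For the measured compounds named here, all three values sit at the same limit (the limit of > 50000 nM in this assay, at which 3 of the 3 values shown sit), so no measured step has a readable size: a step that the two limits leave unreadable from compound 1 to compound 2, a step that the two limits leave unreadable from compound 1 to compound 3 and a step that the two limits leave unreadable from compound 2 to compound 3. Compound 3 therefore stands on a limit only, with the two other values resting at the same limit; no order among the three can be read.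

Compound 4 `O=c1oc2ccccc2c(N2CCN(c3cccc(Cl)c3)CC2)c1CO` is the next compound for this assay. The change from compound 3 is 3-chlorophenyl in place of 4-methoxyphenyl on an amine nitrogen in a ring. The measured steps that bear on it are the two that also exchange the group on the amine nitrogen in the ring, a step that the two limits leave unreadable from compound 1 to compound 2 and a step that the two limits leave unreadable from compound 2 to compound 3; both are unreadable because of the shared limit (the limit of > 50000 nM in this assay, at which 3 of the 3 values shown sit). Every exchange of that group so far has left the value at the limit (the limit of > 50000 nM in this assay, at which 3 of the 3 values shown sit), and the present change is of the same kind.

Compound 4 is therefore expected to give 50000 nM, within 30000 nM to 100000 nM. The expected step of a number no higher from compound 3 to compound 4 (the limit leaves the size open) is estimated as no change beyond the scatter, and a further limit rather than a number is the likely outcome.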

Compound 4, half-maximal cytotoxic concentration: > 50000 nM
Compound 4 ended at the assay's limit; the forecaster's own chance of this, stated with the estimate: 85%; the middle value sits exactly at the limit.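

In this assay compound 4 gives > 50000 nM, a limit and not a number. No step from compound 1, compound 2 or compound 3 to compound 4 can be read, because all the values rest on one limit: the limit of > 50000 nM in this assay, at which 4 of the 4 values shown sit.

The compounds shown leave open how these four compare and whether any exchange of the group on the amine nitrogen in the ring gives a readable value in this assay.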